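The source may hold more compounds than are shown below. What is called first, only, known or untested is meant among the compounds shown, and "the series" means these compounds.

Compound 1 `COC(=O)c1cc(-n2cc(-c3cc(OC)cc(OC)c3)nn2)ccc1O`: in a functional assay on HCT-116 cells (Homo sapiens) for inhibition, read by MTT assay, with a stated time of 2 days, tested at 10 uM (on this read-out lower numbers stand for less inhibition and higher numbers for more inhibition at the one concentration tested (going by the name of the read-out)), compound 1 gives 3%.
Compound 2 `COc1cc(OC)cc(-c2cn(-c3ccc(O)c(C(=O)O)c3)nn2)c1`: in this assay compound 2 gives 2%.

Compound 2 has the lower of the two numbers, and its nearest neighbour is compound 1, but the step of a number 1 percentage points lower from compound 1 to compound 2 (within the scatter) lies within the scatter, so the two values cannot be told apart. Compound 3 `COc1cc(OC)cc(-c2cn(-c3ccc(O)c(C(=O)OCCCc4ccccc4)c3)nn2)c1` differs from compound 2 in one place: 3-phenylpropyl in place of hydrogen on an oxygen next to a carbonyl group. Among the measured compounds shown here, the only measured step, from compound 1 to compound 2, concerns the same oxygen next to a carbonyl group and exchanges methyl for hydrogen; it was within the scatter. For the measured compounds named here, no measured pair shows what a group as large as 3-phenylpropyl does at this oxygen, so the expectation rests on two values that both sit near the floor of the read-out. The step is therefore estimated as a number 4 percentage points higher from compound 2 to compound 3 (within the scatter), not beyond the scatter. Compound 3 is expected to give 6%, in the range 0% to 22%.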

Compound 3, a percentage reported as inhibition, at one concentration (the size of the read-out at that concentration, not a potency): 19%
The estimate for compound 3 lay 13 percentage points below the measured number; the range from low to high includes it.
By their numbers in this assay, from the lowest: compounds 2 and 1 (each within the scatter of the next); then compound 3.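

At the oxygen next to a carbonyl group, hydrogen and methyl could not be told apart in this assay, but 3-phenylpropyl gives a number 17 percentage points higher from compound 2 to compound 3 (beyond the scatter) and, measured against the methyl compound, a number 16 percentage points higher from compound 1 to compound 3 (beyond the scatter). This oxygen can therefore carry a change that moves the read-out beyond the scatter, although compound 3 still gives only 19% at the one concentration tested. Nothing available here bears on the reason for this rise.

The compounds shown leave open whether the step depends on the chain or on the six-membered aromatic ring, which a plain propyl or a benzyl group on this oxygen would separate. They also leave open how a longer chain, or an amine at the end of the chain, would read at this place.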